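This account rests on a few compounds, and the source may have more. Where it says the series, first, only, none or still open, it means among the compounds named here.

Working notes on the series. In a functional assay on QG-56 cells (Homo sapiens) for antiproliferative activity (on this read-out higher numbers stand for weaker inhibition and lower numbers for stronger inhibition), compound 1 `COc1cccc(-c2cc([N+](=O)[O-])cc3cc(C(O)(c4ccc(C#N)cc4)c4cncn4C)oc23)c1` with nitro gives 38.8 nM and compound 2 `COc1cccc(-c2cc(CN(C)C)cc3cc(C(O)(c4ccc(C#N)cc4)c4cncn4C)oc23)c1` with (dimethylamino)methyl gives 142 nM on the shared core. Compound 3 `COc1cccc(-c2cc(C(N)=O)cc3cc(C(O)(c4ccc(C#N)cc4)c4cncn4C)oc23)c1` with carbamoyl gives 8.2 nM as the lowest of the three numbers, and both its steps to the others lie beyond the scatter.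

Compound 4 `COc1cccc(-c2cc(C=O)cc3cc(C(O)(c4ccc(C#N)cc4)c4cncn4C)oc23)c1` is not yet measured, and its change from compound 3 is hydrogen in place of amino on a carbonyl carbon (hydrogen in place of amino on a carbonyl carbon, or carbamoyl to formyl). Within the data shown here, no measured step makes this exact change. The nearest evidence is exchange of the whole group, with a 4.7-fold lower number from compound 1 to compound 3 (0.68 log units; beyond the scatter) for nitro to carbamoyl, a 17-fold lower number from compound 2 to compound 3 (1.24 log units; beyond the scatter) for (dimethylamino)methyl to carbamoyl and a 3.7-fold higher number from compound 1 to compound 2 (0.56 log units; beyond the scatter) for nitro to (dimethylamino)methyl. These steps run from modest to large, and both groups tried in place of carbamoyl give higher numbers. In this assay a modest step to a higher number is therefore expected, smaller than the large gap between compound 2 and compound 3. The estimated step is a 3.0-fold higher number from compound 3 to compound 4 (0.48 log units; beyond the scatter) for this change. For compound 4 the expected value is 25 nM with an estimated range of 9 nM to 75 nM in this series.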

Compound 4, half-maximal inhibitory concentration: 15.2 nM
Beside the measured number, compound 4's estimate is 1.6-fold (0.22 log units) above it, within the range that was stated.
By their numbers in this assay, from the lowest: compounds 3 and 4 (each within the scatter of the next); then compound 1; then compound 2.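

In this assay, hydrogen in place of amino on the carbonyl carbon gives a 1.9-fold higher number from compound 3 to compound 4 (0.27 log units; within the scatter), so carbamoyl and formyl cannot be told apart at this position, and the hydrogen-bond donor that leaves with amino is not required for a number at this level on the shared core. Formyl also stays clear of the other two groups tried on this aromatic carbon, with a 9.3-fold lower number from compound 2 to compound 4 (0.97 log units; beyond the scatter) and a 2.6-fold lower number from compound 1 to compound 4 (0.41 log units; beyond the scatter), so among the four compounds both carbonyl-bearing groups give lower numbers than nitro and (dimethylamino)methyl, and none of the four goes against this. No measurement at hand bears on why these numbers fall as they do.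

From the compounds shown here alone, whether a carbonyl on this carbon is what matters remains open: hydroxymethyl would separate the carbonyl from the rest of the group, while a carboxylic acid, a methyl ester, an acetyl or an N-methyl amide would show how far the group attached to the carbonyl carbon can change. The compounds shown also leave open whether the equivalence of carbamoyl and formyl holds in any assay other than this cell read-out.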